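The source may hold more compounds than are shown below. What is called first, only, known or untested is meant among the compounds shown, and "the series" means these compounds.

In an assay on Ltk cells for inhibition of metabotropic glutamate receptor 5 (Homo sapiens), read by fluorescence (on this read-out higher numbers stand for weaker inhibition and lower numbers for stronger inhibition), the three measured compounds stand as follows:
compound 1 `CN(C)c1nc(N)c(C(=O)Nc2ccccn2)nc1Cl` gives 134 nM
compound 2 `Nc1nc(N2CCCCC2)c(Cl)nc1C(=O)Nc1ccccn1` gives 103 nM
compound 3 `Nc1nc(N)c(C(=O)Nc2ccccn2)nc1Cl` gives 3800 nM

Compound 3 has the highest number of the three and so the weakest inhibition: a 28-fold higher number from compound 1 to compound 3 (1.45 log units; beyond the scatter) and a 37-fold higher number from compound 2 to compound 3 (1.57 log units; beyond the scatter), both beyond the scatter. Compound 4 `Nc1ncc(Cl)nc1C(=O)Nc1ccccn1` differs from compound 3 in one place: hydrogen in place of amino on an aromatic carbon, next to the ring nitrogen and ortho to a chloro group. Among the measured compounds shown here, no measured step removes the amino group outright. The two steps that touch this position, a 28-fold higher number from compound 1 to compound 3 (1.45 log units; beyond the scatter) and a 37-fold higher number from compound 2 to compound 3 (1.57 log units; beyond the scatter), show that what sits there sways this assay strongly, and the amino group gave the higher number. Taking it away is expected to raise the number further, by a 1.8-fold higher number from compound 3 to compound 4 (0.27 log units; within the scatter). Compound 4 is therefore estimated at 7000 nM, within 1500 nM to 30000 nM.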

Compound 4, half-maximal inhibitory concentration: 11 nM
The estimate for compound 4 lay 640-fold (2.80 log units) above the measured number; the whole stated range lies above it.
By their numbers in this assay, from the lowest: compound 4; then compounds 2 and 1 (each within the scatter of the next); then compound 3.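

Plain hydrogen at this position, next to the ring nitrogen, gives a lower number in this assay than each of the three groups shown there: amino (a 350-fold lower number from compound 3 to compound 4 (2.54 log units; beyond the scatter)), dimethylamino (a 12-fold lower number from compound 1 to compound 4 (1.09 log units; beyond the scatter)) and piperidin-1-yl (a 9.4-fold lower number from compound 2 to compound 4 (0.97 log units; beyond the scatter)). The earlier compounds shown here compared these groups only with one another, which singled out amino as the poor one; now all three give higher numbers than hydrogen. Nothing measured here explains the gain.

As far as these compounds go, whether a small group such as methyl or fluoro could match hydrogen here remains open. So does whether the gain would survive replacing the chloro group with methyl.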